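Side-chain variation on the shared core in Caco-2 activation

The source may report more compounds than this note shows. Statements on the series, on what has been measured and on what is new or still open speak of the compounds shown alone.

Measured so far:
compound 1 `COc1cc(/C=C/C(=O)/C=C(/C=C/c2ccc(O)c(OC)c2)NCCO)ccc1O` — in a functional assay on Caco-2 cells (Homo sapiens) for activation, read by fluorescence, tested at 10 uM (on this read-out higher numbers stand for a weaker effect at the one concentration tested and lower numbers for a stronger effect), compound 1 gives 96.6%
compound 2 `COc1cc(/C=C/C(=O)/C=C(/C=C/c2ccc(O)c(OC)c2)NCCCO)ccc1O` — in this assay compound 2 gives 91%

Among the measured compounds shown here, compound 2 holds the lowest of the two numbers in this assay, and its only neighbour is compound 1; the single step available is a number 5.6 percentage points lower from compound 1 to compound 2 (within the scatter), which does not leave the scatter. Both numbers sit high, so neither compound shows more than a weak effect at the one concentration tested.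

The next compound, compound 3 `COCCNC(=C\C(=O)/C=C/c1ccc(O)c(OC)c1)/C=C/c1ccc(O)c(OC)c1`, differs from compound 2 as follows: methoxy in place of hydroxymethyl on a saturated chain carbon, two bonds along the chain from an amine nitrogen.

For the measured compounds named here, only the step from compound 1 to compound 2 bears on this change, since it altered the same chain at the same place, and it stayed within the scatter. Going by the values given here, there is no measured step in which a hydroxyl group is exchanged for a methoxy group, so nothing in the data points to a shift in either direction. The expectation is therefore a step within the scatter, estimated as a number 2 percentage points higher from compound 2 to compound 3 (within the scatter).

Compound 3 is expected to give 93% in this assay, with an estimated range from 80% to 105%.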

Compound 3, a percentage reported as activity, at one concentration (the size of the read-out at that concentration, not a potency): 75.6%
The estimate for compound 3 lay 17.4 percentage points above the measured number; the whole stated range lies above it.
By their numbers in this assay, from the lowest: compound 3; then compounds 2 and 1 (each within the scatter of the next).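

In this assay this side chain now gives a change beyond the scatter: a number 15.4 percentage points lower from compound 2 to compound 3 (beyond the scatter) with methoxy in place of hydroxymethyl on a saturated chain carbon, two bonds along the chain from an amine nitrogen, whereas the earlier step of a number 5.6 percentage points lower from compound 1 to compound 2 (within the scatter) stayed within it. The comparison with compound 1 isolates a different reading of the same chain, a number 21 percentage points lower from compound 1 to compound 3 (beyond the scatter) with methyl in place of hydrogen on an oxygen on a saturated carbon, so within these three compounds the shift toward a stronger effect appears only with the methoxy end group, and both steps remain modest. No supporting measurement bears on why this end group shifts the read-out.

Open, on these data alone, is whether the shift follows the methoxy group specifically or would extend to a longer ether such as 2-ethoxyethyl or to a 3-methoxypropyl chain. Also open, as far as these compounds go, is how the same position responds to an end group of another kind, such as an amine or a carboxylic acid.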